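The compounds below may be only part of what the source reports. "The series", "measured", "known", "first", "only" and "open" are said of these compounds alone.

Working notes on the series in a functional assay on CHO-K1 cells for antagonist activity at transient receptor potential cation channel subfamily V member 1 (Homo sapiens), read by FLIPR; a higher number here means a weaker inhibitor, a lower number a stronger inhibitor.

Of the compounds shown here, three have numbers so far. Compound 1 `CCCCNc1nc(C(F)(F)F)ccc1CNC(=O)C(C)c1ccc(NS(C)(=O)=O)c(F)c1` gives 9.1 nM in this assay. Within the data shown here, compound 2 `CC1CCC(Nc2nc(C(F)(F)F)ccc2CNC(=O)C(C)c2ccc(NS(C)(=O)=O)c(F)c2)CC1` gives 27.2 nM, and the single one-place step known, a 3.0-fold higher number from compound 1 to compound 2 (0.48 log units; beyond the scatter), concerns the group on the nitrogen on the aromatic ring. Compound 3 `Cc1cccc(N2CCN(c3nc(C(F)(F)F)ccc3CNC(=O)C(C)c3ccc(NS(C)(=O)=O)c(F)c3)CC2)c1` gives 3.4 nM and stands lowest of the three, its step to compound 1 and its step to compound 2 both beyond the scatter, so it is the strongest inhibitor measured here.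

Compound 4 `CC(C(=O)NCc1ccc(C(F)(F)F)nc1N1CCN(Cc2ccccc2)CC1)c1ccc(NS(C)(=O)=O)c(F)c1` is not yet measured. It differs from compound 3 by benzyl in place of 3-methylphenyl on an amine nitrogen in a ring. Among the measured compounds shown here, no measured step touches this position; the step from compound 1 to compound 2 sits elsewhere and says nothing direct about the ring nitrogen altered here. The expectation therefore rests on compound 3 alone, with a wide range, and a modest move toward a higher number is estimated, a 2.4-fold higher number from compound 3 to compound 4 (0.37 log units; beyond the scatter). Compound 4 is estimated at 8 nM, within 2.5 nM to 30 nM.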

Compound 4, inhibition constant: 8.8 nM
The estimate for compound 4 lay 1.1-fold (0.04 log units) below the measured number; low and high end bracket the measured number.
By their numbers in this assay, from the lowest: compound 3; then compounds 4 and 1 (each within the scatter of the next); then compound 2.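

In this assay, among these compounds, benzyl in place of 3-methylphenyl on the amine nitrogen in the ring gives a 2.6-fold higher number from compound 3 to compound 4 (0.41 log units; beyond the scatter), the first reading at this position. The two groups have the same atoms and the same counts of donors and acceptors, so joining those atoms differently is enough to shift the number beyond the scatter in this matched pair. Nothing available bears on the reason for this step.

Going by these compounds, whether plain phenyl or 2-phenylethyl on the same nitrogen would stand nearer compound 3 or compound 4 remains open. Also open, on these data alone, is whether the methyl of 3-methylphenyl matters at all, which a comparison with 3-chlorophenyl or 4-methylphenyl would begin to address.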